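Working notes on four compounds in one cytotoxicity assay

A few compounds are considered here, and "the series" means these few. Any claim that something is new, unique, unknown or untested is made for them only; others in the source may bear on it.

Compound 1 `Cc1ccc(S(=O)(=O)N2C/C(=C\c3ccccc3F)C(=O)/C(=C/c3ccccc3F)C2)cc1` is the starting point of this small set; in an ADME assay on L02 cells (Homo sapiens) for cytotoxicity, read by MTT assay, with a stated time of 24 h (on this read-out lower numbers stand for stronger inhibition and higher numbers for weaker inhibition), compound 1 gives 16700 nM. Compound 2 `O=C1/C(=C/c2ccccc2F)CN(S(=O)(=O)c2ccc(O[N+](=O)[O-])cc2)C/C1=C\c1ccccc1F` carries the change (nitrooxy in place of methyl on an aromatic carbon), and in this assay compound 2 gives 15500 nM. The step of a 1.1-fold lower number from compound 1 to compound 2 (0.03 log units; within the scatter) is within the scatter, so the two values cannot be told apart. Compound 3 `Cc1ccc(S(=O)(=O)N2C/C(=C\c3ccc(F)cc3)C(=O)/C(=C/c3ccc(F)cc3)C2)cc1` has a different core from compound 1; the difference between the two cores is not broken down here. In this assay compound 3 gives 14000 nM, a value that lies within the scatter of both compound 1 and compound 2, so no order among the three can be read from these numbers. Compound 4 `O=C1/C(=C/c2ccc(F)cc2)CN(S(=O)(=O)c2ccc(O[N+](=O)[O-])cc2)C/C1=C\c1ccc(F)cc1` has not been measured. It stands to compound 3 exactly as compound 2 stands to compound 1: the change nitrooxy in place of methyl on an aromatic carbon is the same change at the same place. Because the measured step of a 1.1-fold lower number from compound 1 to compound 2 (0.03 log units; within the scatter) stayed within the scatter, the expected step of a 1.1-fold lower number from compound 3 to compound 4 (0.03 log units; within the scatter) is taken to be equally small. Compound 4 is therefore estimated at 13000 nM, with a likely range from 7000 nM to 26000 nM.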

Compound 4, half-maximal inhibitory concentration: 16200 nM
Estimate against measurement, compound 4: 1.2-fold (0.10 log units) below; the range from low to high includes it.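

In this assay, nitrooxy in place of methyl on an aromatic carbon gives a 1.2-fold higher number from compound 3 to compound 4 (0.06 log units; within the scatter), so no change can be read on the core of compound 3. Set beside the earlier step, the two cores do not separate: the same change on two cores in this assay, a 1.1-fold lower number (0.03 log units; within the scatter) from compound 1 to compound 2 and a 1.2-fold higher number (0.06 log units; within the scatter) from compound 3 to compound 4, 1.2-fold (0.10 log units) apart, within the scatter of two such steps. For the compounds shown here, for these two cores and this single read-out, the change therefore carries across with no step beyond the scatter, but only two pairs stand here, which does not show that it would stay this small on any further core or in any other assay.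

Still open, as far as these compounds go, is whether another group at the same place, such as an amine or a carboxylic acid, would shift the number beyond the scatter. Also open, from the compounds shown here alone, is what a chlorine atom or a methoxy group in place of fluorine would do on either core.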